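This account rests on a few compounds, and the source may have more. Where it says the series, first, only, none or still open, it means among the compounds named here.

Measured compounds:
Compound 1 `COc1cc2c(Oc3ccc(NC(=O)c4nnn(-c5ccccc5)c4C)cc3F)ccnc2cc1OCCCN1CCCC1` gives 1000 nM in a functional assay on U-87MG ATCC cells (Homo sapiens) for cytotoxicity, read by MTT assay, with a stated time of 72 h; on this read-out lower numbers stand for stronger inhibition and higher numbers for weaker inhibition.
Compound 2 `COc1cc2c(Oc3ccc(NC(=O)c4nnn(-c5ccccc5C(F)(F)F)c4C)cc3F)ccnc2cc1OCCCN1CCCC1` gives 1060 nM in this assay.
Compound 3 `COc1cc2c(Oc3ccc(NC(=O)c4nnn(-c5ccc(C)cc5)c4C(F)(F)F)cc3F)ccnc2cc1OCCCN1CCCC1` has as its entry in this assay only "not determined" (no result reported), so no number is available for it.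

Compound 1 holds the lower of the two numbers available, and compound 2 sits a short distance away: a 1.1-fold higher number from compound 1 to compound 2 (0.03 log units; within the scatter). Compound 4 `COc1cc2c(Oc3ccc(NC(=O)c4nnn(-c5ccccc5)c4C)cc3F)ccnc2cc1OCCCN1CCCCC1` differs from compound 1 in the chain that hangs from the core: piperidin-1-yl in place of pyrrolidin-1-yl on a saturated chain carbon, three bonds along the chain from an oxygen on an aromatic ring. Going by the values given here, no measured step touches this part of the molecule; the single step recorded concerns a trifluoromethyl on an aromatic ring and stays within the scatter. With nothing to point either way, the expected outcome for compound 4 is no step beyond the scatter, no change at the digits printed from compound 1 to compound 4 (within the scatter). Compound 4 is therefore estimated at 1000 nM, within a range of 400 nM to 2500 nM.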

Compound 4, half-maximal inhibitory concentration: 1130 nM
For compound 4 the middle estimate is 1.1-fold (0.05 log units) below the measured one, within the range that was stated.
By their numbers in this assay, from the lowest: compounds 1, 2 and 4 (each within the scatter of the next).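

Replacing pyrrolidin-1-yl with piperidin-1-yl on the saturated chain carbon, three bonds along the chain from an oxygen on an aromatic ring, gives a 1.1-fold higher number from compound 1 to compound 4 (0.05 log units; within the scatter) in this assay and thus stays within the scatter. Going by these compounds alone, this is the first reading at this position, and it shows that the pair of ring amines at the chain end can be exchanged here without a step beyond the scatter. No supporting measurement offers an explanation for this result.

As far as these compounds go, it remains open whether a morpholine ring, a dimethylamino group or a carboxylic acid at the chain end would behave the same way. A shorter or longer chain carrying the piperidin-1-yl group is also untested among the compounds shown.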